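This account rests on a few compounds, and the source may have more. Where it says the series, first, only, none or still open, it means among the compounds named here.

Two close relatives share the same core and differ only in the heteroaromatic ring that carries the rest of the molecule. Compound 1 `S=C(NCc1cccnc1)SCCc1nc2ccccc2o1` was tested in a functional assay on MDA-MB-468 cells (Homo sapiens) for cytotoxicity, read by resazurin assay, with a stated time of 72 h (on this read-out higher numbers stand for weaker inhibition and lower numbers for stronger inhibition), where compound 1 gives 4300 nM. Compound 2 `S=C(NCc1cccnc1)SCCc1nnc(-c2ccccc2)o1` was tested in the same way, and in this assay compound 2 gives 2770 nM. Of the two numbers, that of compound 2 is the lower, but the gap to compound 1 lies within the scatter of repeated measurements, so the two compounds cannot be told apart on these data.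

Compound 3 `S=C(NCc1cccnc1)SCCc1nnc(-c2cnccn2)o1` is the next member of the set. Against compound 2 the counted difference is pyrazin-2-yl in place of phenyl on an aromatic carbon. Within the data shown here, no step between measured compounds of this kind is available, so there is nothing from which to read off how large a change to expect. The estimate for compound 3 therefore keeps close to its neighbour: in this assay compound 3 is expected to give about 3000 nM, with a range from 1200 nM to 8000 nM. This means an expected step of a 1.1-fold higher number from compound 2 to compound 3 (0.03 log units; within the scatter) that stays within the scatter.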

Compound 3, half-maximal inhibitory concentration: 1710 nM
Beside the measured number, compound 3's estimate is 1.8-fold (0.24 log units) above it; low and high end bracket the measured number.
By their numbers in this assay, from the lowest: compounds 3, 2 and 1 (each within the scatter of the next, the first and the last beyond it).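

In this assay, among these compounds, the change at this position, on the aromatic carbon of the five-membered aromatic ring with 2 nitrogen and 1 oxygen, gives a 1.6-fold lower number from compound 2 to compound 3 (0.21 log units; within the scatter), and this is the first step between measured compounds that differ in one place. The swap keeps the number of heavy atoms and the six-membered aromatic ring, but it replaces two ring carbons with nitrogens and adds 2 hydrogen-bond acceptors, and even so compound 2 and compound 3 cannot be told apart in this measurement. At least for this one exchange, then, the position accepts pyrazin-2-yl in place of phenyl without a change that stands clear of the normal variation between repeats, although nothing shown explains why the step has this size.

A single step cannot show whether any other group on this carbon would produce a clear change, for instance a ring-free chain such as butyl, or a phenyl that carries an amine or a carboxylic acid. It also leaves open whether the same exchange would give a similar step on a different core or in another kind of test.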